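Working notes: chloro for trifluoromethyl on the shared core

This account rests on a few compounds, and the source may have more. Where it says the series, first, only, none or still open, it means among the compounds named here.

Measured compounds:
compound 1 `CC(c1ccc(-c2ccccc2)c(F)c1)c1nnc2n1N=C(c1ccccc1)CS2`: 7400 nM
compound 2 `CC(c1ccc(-c2ccccc2)c(F)c1)c1nnc2n1N=C(c1ccc(C(F)(F)F)cc1)CS2`: 4300 nM

In a functional assay on MCF7 cells (Homo sapiens) for inhibition, read by sulforhodamine B assay, with a stated time of 72 h (on this read-out higher numbers stand for weaker inhibition and lower numbers for stronger inhibition), compound 2 gives 4300 nM, and compound 1 sits within the scatter of it. Within the data shown here, the only measured step, a 1.7-fold lower number from compound 1 to compound 2 (0.24 log units; within the scatter), is itself within the scatter. Compound 3 `CC(c1ccc(-c2ccccc2)c(F)c1)c1nnc2n1N=C(c1ccc(Cl)cc1)CS2` follows by the change (chloro in place of trifluoromethyl on an aromatic carbon). Among the measured compounds shown here, no measured step covers this swap; the sole step is small, so the step of a 1.2-fold higher number from compound 2 to compound 3 (0.07 log units; within the scatter) is expected to stay within the scatter, with no clear direction. Compound 3 is estimated at 5000 nM, between 2000 nM and 12000 nM.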

Compound 3, half-maximal inhibitory concentration: 8700 nM
Compound 3: middle estimate off by 1.7-fold (0.24 log units), on the low side, and the stated range covers the measured number.
By their numbers in this assay, from the lowest: compounds 2, 1 and 3 (each within the scatter of the next, the first and the last beyond it).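

Among these compounds, at this aromatic carbon, para to a large group, the series now has its only step beyond the scatter, and a modest one: (in this assay) the change to 4-chlorophenyl gives a 2.0-fold higher number from compound 2 to compound 3 (0.31 log units; beyond the scatter). Chloro in place of hydrogen at the same carbon gives a 1.2-fold higher number from compound 1 to compound 3 (0.07 log units; within the scatter), so that replacement does not separate the two compounds. No available evidence explains the difference between trifluoromethyl and chloro.

Still open, from the compounds shown here alone, is how an amine or a carboxylic acid at this carbon would read in this assay. Going by these compounds, whether the step from trifluoromethyl to chloro carries over to other cores also remains open.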